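The source may hold more compounds than are shown below. What is called first, only, known or untested is meant among the compounds shown, and "the series" means these compounds.

Going by the values given here, in a functional assay on CCRF-CEM cells (Homo sapiens) for inhibition, read by sulforhodamine B assay, with a stated time of 48 h, tested at 10 uM (a higher number here means a weaker effect of the compound at the concentration tested, a lower number a stronger effect), compound 2 `COc1cc(Cl)cc(-c2nn(-c3cccc(NC(=O)Nc4ccc(Cl)c(C(F)(F)F)c4)c3)cc2-c2ccncc2)c1` gives 1.88%, the lower of the two numbers so far; compound 1 `O=C(Nc1cccc(-n2cc(-c3ccncc3)c(-c3cc(O)cc(Cl)c3)n2)c1)Nc1ccc(Cl)c(C(F)(F)F)c1` gives 9.31%, and the step of a number 7.4 percentage points lower from compound 1 to compound 2 (within the scatter) lies within the scatter. Compound 3 `COc1cc(Cl)cc(-c2nn(-c3cccc(NC(=O)c4cccc(C(F)(F)F)c4)c3)cc2-c2ccncc2)c1` differs from compound 2 in one place: 3-(trifluoromethyl)phenyl in place of (4-chloro-3-(trifluoromethyl)phenyl)amino on a carbonyl carbon. Among the compounds with values here, the only measured step, from compound 1 to compound 2, touches a different part of the molecule and so says nothing about this change; no other comparison exists. The expectation for compound 3 is therefore loosely held, a step of a number 33.1 percentage points higher from compound 2 to compound 3 (beyond the scatter) towards a weaker effect, with a wide range. Compound 3 is estimated at 35%, between 0% and 85%.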

Compound 3, a percentage reported as activity, at one concentration (the size of the read-out at that concentration, not a potency): 42.3%
Estimate against measurement, compound 3: 7.3 percentage points below, and the stated range covers the measured number.
By their numbers in this assay, from the lowest: compounds 2 and 1 (each within the scatter of the next); then compound 3.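

On a carbonyl carbon, 3-(trifluoromethyl)phenyl in place of (4-chloro-3-(trifluoromethyl)phenyl)amino gives a number 40.4 percentage points higher from compound 2 to compound 3 (beyond the scatter) in this assay and so shows that this end of the molecule matters, which the change on the oxygen could not show. The swap removes a nitrogen with its hydrogen-bond donor and a chlorine together, so this one step cannot separate them. No measurement here offers an explanation for the weaker effect. Still open, going by these compounds, is how 4-chloro-3-(trifluoromethyl)phenyl or plain phenylamino on that carbonyl carbon would compare, which would tell the chlorine and the nitrogen apart.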